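Adding a fluoro group to compound 2

The source may report more compounds than this note shows. Statements on the series, on what has been measured and on what is new or still open speak of the compounds shown alone.

Compound 1 `C=C(Br)C(=O)Nc1cccc(/C=C/C(=O)Nc2ccc(F)cc2)c1`: 16800 nM
Compound 2 `C=C(Br)C(=O)Nc1cccc(/C=C/C(=O)Nc2cccc(F)c2)c1`: 1200 nM

Both values come from a functional assay on HeLa cells (Homo sapiens) for inhibition, read by MTT assay, with a stated time of 72 h (a lower number here means a stronger inhibitor, a higher number a weaker inhibitor), and compound 2 holds the lower number of the two. Compound 3 `C=C(Br)C(=O)Nc1cccc(/C=C/C(=O)Nc2ccc(F)c(F)c2)c1` differs from compound 2 by fluoro in place of hydrogen on an aromatic carbon, giving 3,4-difluorophenyl. Among the measured compounds shown here, one measured step bears on this, the large 14-fold lower number from compound 1 to compound 2 (1.15 log units; beyond the scatter), which lies beyond the scatter. The new group contains both fluoro placements from that step, so a higher number is expected, though a smaller change than that step. The expected step is a 2.1-fold higher number from compound 2 to compound 3 (0.32 log units; beyond the scatter). Compound 3 is estimated at 2500 nM, with an expected range of 700 nM to 9000 nM.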

Compound 3, half-maximal inhibitory concentration: 1900 nM
The estimate for compound 3 lay 1.3-fold (0.12 log units) above the measured number, and the stated range covers the measured number.
By their numbers in this assay, from the lowest: compounds 2 and 3 (each within the scatter of the next); then compound 1.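

In this assay, adding fluoro to the 3-fluorophenyl ring gives a 1.6-fold higher number from compound 2 to compound 3 (0.20 log units; within the scatter) and so leaves the two numbers within the usual scatter of each other. Fluoro in place of hydrogen on the 4-fluorophenyl ring instead gives an 8.8-fold lower number from compound 1 to compound 3 (0.95 log units; beyond the scatter) and shows that the effect of adding this one atom depends on the fluoro already on the ring. Nothing measured here explains this dependence. Still open, on these data alone, is whether chloro or methoxy on this aromatic carbon would match fluoro, with or without the neighbouring fluoro group.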